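A few compounds are considered here, and "the series" means these few. Any claim that something is new, unique, unknown or untested is made for them only; others in the source may bear on it.

Compound 3 `CC(=O)n1cc(/C=C(/C(=O)O)c2ccc(Cl)cc2)c2cc(OCc3ccccc3)ccc21` is one of three close relatives that share a core and differ only in the aryl group on the double-bonded chain carbon. In a functional assay on KB cells (Homo sapiens) for cytotoxicity, read by MTT assay, with a stated time of 72 h (on this read-out higher numbers stand for weaker inhibition and lower numbers for stronger inhibition), compound 3 gives only a limit of the assay, > 100000 nM. Compound 1 `COc1cc(/C(=C\c2cn(C(C)=O)c3ccc(OCc4ccccc4)cc23)C(=O)O)cc(OC)c1OC` likewise gives a limit, > 100000 nM. Compound 2 `COc1ccccc1/C(=C\c1cn(C(C)=O)c2ccc(OCc3ccccc3)cc12)C(=O)O` also gives a limit, > 100000 nM. Because all three sit at the limit of > 100000 nM in this assay, at which 3 of the 3 values shown sit, the steps a step that the two limits leave unreadable from compound 1 to compound 2, a step that the two limits leave unreadable from compound 1 to compound 3 and a step that the two limits leave unreadable from compound 2 to compound 3 cannot be sized. Compound 4 `COc1ccc(/C(=C\c2cn(C(C)=O)c3ccc(OCc4ccccc4)cc23)C(=O)O)cc1` differs from compound 3 by methoxy in place of chloro on an aromatic carbon. For the measured compounds named here, none of the measured steps shows a readable size, so no direction can be drawn from them. The step of a number no higher from compound 3 to compound 4 (the limit leaves the size open) is therefore expected to stay inside the scatter. For compound 4 the estimate in this assay is 100000 nM, with a range from 30000 nM to 300000 nM, most likely again reported only as a limit.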

Compound 4, half-maximal inhibitory concentration: > 100000 nM
Compound 4: a limit, no number; the forecaster's own chance of this, stated with the estimate: 80%; the middle value sits exactly at the limit.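

For the compounds shown here, no step between compound 4 and compound 1, compound 2 or compound 3 can be read, because each result is only a limit: the limit of > 100000 nM in this assay, at which 4 of the 4 values shown sit. Whether the aryl group changes cytotoxicity on this shared core remains open.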